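The compounds below may be only part of what the source reports. "The series", "measured", "known", "first", "only" and "open" are said of these compounds alone.

Compound 1 `COc1cc(-c2nn(-c3cccc(NC(=O)Nc4ccc(Cl)c(Cl)c4)c3)cc2-c2ccncc2)ccc1Cl` and compound 2 `COc1cc(-c2nn(-c3cccc(NC(=O)Nc4ccc(Cl)c(C(F)(F)F)c4)c3)cc2-c2ccncc2)ccc1Cl` share one core and differ only by trifluoromethyl in place of chloro on an aromatic carbon. In a functional assay on K562 cells (Homo sapiens) for inhibition, read by sulforhodamine B assay, with a stated time of 48 h (a lower number here means a stronger inhibitor of growth, a higher number a weaker inhibitor of growth), compound 1 gives > 50000 nM, a limit of the assay. In this assay compound 2 gives > 32500 nM, also a limit. Hence a step that the two limits leave unreadable from compound 1 to compound 2; compound 2 stands at the limit of > 32500 nM in this assay, at which 1 of the 2 values shown sits, with no number behind it. Compound 3 `COc1cc(-c2nn(-c3cccc(NC(=O)c4ccccc4)c3)cc2-c2ccncc2)ccc1Cl` differs from compound 2 by phenyl in place of (4-chloro-3-(trifluoromethyl)phenyl)amino on a carbonyl carbon. Within the data shown here, no measured step bears on this change, and compound 2 gives only a limit, so no direction in this assay can be read. Compound 3 is expected at 50000 nM, within 10000 nM to 100000 nM, most likely again a limit. The estimated step that the limit leaves unreadable from compound 2 to compound 3 is nominal only.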

Compound 3, concentration for total growth inhibition: > 100000 nM
Compound 3: a limit, no number (the forecaster's own chance of this, stated with the estimate: 80%); middle value at least 2.0-fold (0.30 log units) away from the limit.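

Among these compounds, compound 1, compound 2 and compound 3 each give only a limit in this assay, so no step among them can be read. The compounds shown leave open whether any change to the shared core gives a numerical value.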